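Swapping one aryl group on a well-absorbed compound

The source may report more compounds than this note shows. Statements on the series, on what has been measured and on what is new or still open speak of the compounds shown alone.

Compound 1 `CCOc1cc([C@](O)(CCN(C)C)[C@@H](c2cc3cc(Br)ccc3nc2OC)c2ccnc(OC)c2OC)cc(OC)n1` gives 70%
Compound 2 `COc1cc([C@](O)(CCN(C)C)[C@@H](c2cc3cc(Br)ccc3nc2OC)c2ccnc(OC)c2OC)cc(OC(C)C)n1` gives 22%
Compound 3 `COc1cccc([C@H](c2cc3cc(Br)ccc3nc2OC)[C@@](O)(CCN(C)C)c2cc(SC)nc(SC)c2)c1F` gives 66%

In an ADME assay on the whole organism (Mus musculus, strain CD-1) for pharmacokinetics, at a dose of 10 mg/kg by the oral route (on this read-out higher numbers stand for higher oral bioavailability and lower numbers for lower oral bioavailability), compound 3 matches compound 1 within the scatter and lies well above compound 2. Compound 4 `COc1nc2ccc(Br)cc2cc1[C@@H](c1ccnc(OC)c1OC)[C@@](O)(CCN(C)C)c1cc(SC)nc(SC)c1` differs from compound 3 at one place: 2,3-dimethoxypyridin-4-yl in place of 2-fluoro-3-methoxyphenyl on a saturated chain carbon bound to an aromatic carbon and a saturated chain carbon with 2,3-dimethoxypyridin-4-yl in place of 2-fluoro-3-methoxyphenyl on a saturated chain carbon bound to an aromatic carbon and a saturated chain carbon. For the measured compounds named here, the only measured step, a number 48 percentage points lower from compound 1 to compound 2 (beyond the scatter), is large and joins two compounds carrying 2,3-dimethoxypyridin-4-yl, but it lies at another place, so it sets no direction here. The expected outcome in this assay is a number 6 percentage points lower from compound 3 to compound 4 (within the scatter) and thus no step beyond the scatter. Compound 4 is estimated at 60% (expected range 30% to 82%).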

Compound 4, oral bioavailability: 41%
Compound 4: middle estimate off by 19 percentage points, on the high side; measured number inside the range.
By their numbers in this assay, from the lowest: compound 2; then compound 4; then compounds 3 and 1 (each within the scatter of the next).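

In this assay the aryl group at this place clearly counts: a number 25 percentage points lower from compound 3 to compound 4 (beyond the scatter) comes with 2,3-dimethoxypyridin-4-yl in place of 2-fluoro-3-methoxyphenyl. With 2,3-dimethoxypyridin-4-yl kept, the sulfur-bearing group of compound 4 sits on middle ground, with a number 19 percentage points higher from compound 2 to compound 4 (beyond the scatter) and a number 29 percentage points lower from compound 1 to compound 4 (beyond the scatter) against the two oxygen-bearing groups. No measurement here accounts for these shifts.

Whether this swap costs as much alongside other groups stays open, as compound 3 and compound 4 are the only such pair shown. From the compounds shown here alone, how a plain phenyl or an aminopyridine would fare at this place also stays open.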